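Ring Growth at the Amide Nitrogen of a Hydroxamate

The compounds below may be only part of what the source reports. "The series", "measured", "known", "first", "only" and "open" are said of these compounds alone.

Compound 1 `O=C(CCCCCCn1cc(C(=O)Nc2ccc(Cl)cc2Cl)c2ccccc21)NO` and compound 2 `O=C(CCCCCCn1cc(C(=O)NC2CCCCCC2)c2ccccc21)NO` share a core and differ only in the group on an amide-type nitrogen. In an assay on isolated protein for inhibition of protein deacetylase HDAC6 (Homo sapiens), read by fluorescence, with a stated time of 60 min (on this read-out lower numbers stand for stronger inhibition and higher numbers for weaker inhibition), compound 1 gives 3.73 nM, and in this assay compound 2 gives 2.11 nM. Compound 2 stands at the lowest of the two numbers shown, yet the step of a 1.8-fold lower number from compound 1 to compound 2 (0.25 log units; within the scatter) lies within the scatter, so nothing separates the pair. Compound 3 `O=C(CCCCCCn1cc(C(=O)NC2CCCCCCC2)c2ccccc21)NO` has not been measured; it carries cyclooctyl in place of cycloheptyl on an amide-type nitrogen. Going by the values given here, the single measured step at this position exchanged an aromatic ring for a non-aromatic one and moved nothing beyond the scatter, whereas the present change adds one carbon to a non-aromatic ring, which no measured step tests directly. The expected step of a 1.0-fold higher number from compound 2 to compound 3 (0.02 log units; within the scatter) in this assay is therefore none beyond the scatter. Compound 3 is expected to give 2.2 nM, within a range from 0.9 nM to 5.5 nM.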

Compound 3, half-maximal inhibitory concentration: 1.8 nM
Beside the measured number, compound 3's estimate is 1.2-fold (0.09 log units) above it; the measured number falls inside the stated range.
By their numbers in this assay, from the lowest: compounds 3, 2 and 1 (each within the scatter of the next, the first and the last beyond it).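

Adding one carbon to the non-aromatic ring, cyclooctyl in place of cycloheptyl on the amide-type nitrogen, gives in this assay a 1.2-fold lower number from compound 2 to compound 3 (0.07 log units; within the scatter); this first direct test of ring size therefore does not separate the two compounds. Cyclooctyl in place of 2,4-dichlorophenyl gives a 2.1-fold lower number from compound 1 to compound 3 (0.32 log units; beyond the scatter), making it the first step at this position to pass the scatter, although only modestly, while cycloheptyl in place of 2,4-dichlorophenyl gives a 1.8-fold lower number from compound 1 to compound 2 (0.25 log units; within the scatter) and stays within it. No measured evidence is available to explain these numbers.

The compounds shown leave open whether smaller rings such as cyclopentyl or cyclohexyl, or an open chain such as n-octyl, would give similar numbers on this nitrogen. From the compounds shown here alone, it also remains open whether an amine or a carboxylic acid on the cyclooctyl ring would keep them there.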